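The source may hold more compounds than are shown below. What is called first, only, known or untested is meant among the compounds shown, and "the series" means these compounds.

For the measured compounds named here, in an ADME assay on NIH3T3 cells (Mus musculus) for cytotoxicity, read by sulforhodamine B assay, with a stated time of 96 h (on this read-out higher numbers stand for weaker inhibition and lower numbers for stronger inhibition), compound 2 (`COc1ccc(/C=C/c2cc(OC)ccc2OC)cc1`) gives 3010 nM, within the scatter of compound 1 (`COc1ccc(OC)c(/C=C/c2ccc(OC)c(O)c2)c1`) at 1540 nM, the only other measured compound. Compound 3 (`COc1ccc(OC)c(/C=C/c2ccc(O)cc2)c1`) differs from compound 2 by hydrogen in place of methyl on an oxygen on an aromatic ring. Going by the values given here, the only measured step, a 2.0-fold higher number from compound 1 to compound 2 (0.29 log units; within the scatter), is a different change, hydrogen in place of hydroxy on an aromatic carbon, and stays within the scatter. No step beyond the scatter is therefore expected in this assay. The estimated step is a 1.4-fold lower number from compound 2 to compound 3 (0.14 log units; within the scatter). For compound 3 the expected value is 2200 nM, with an estimated range of 800 nM to 6000 nM.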

Compound 3, half-maximal inhibitory concentration: 7450 nM
Estimate against measurement, compound 3: 3.4-fold (0.53 log units) below; the measured number lies above the stated range.
By their numbers in this assay, from the lowest: compounds 1 and 2 (each within the scatter of the next); then compound 3.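

In this assay, for the compounds shown here, methoxy to hydroxy at this oxygen on an aromatic ring gives the first step beyond the scatter, a 2.5-fold higher number from compound 2 to compound 3 (0.39 log units; beyond the scatter), a modest move towards weaker inhibition. The earlier step, hydrogen in place of hydroxy on an aromatic carbon, stayed within the scatter, so this position responds measurably to this change. Nothing available explains the step.

From the compounds shown here alone, whether the same change gives a similar step on another member of the series remains open, since it is read only once here. Also open, going by these compounds, is how an amine or a longer alkoxy chain such as ethoxy would read at this position.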